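The compounds below may be only part of what the source reports. "The series", "measured", "known", "first", "only" and "open" are said of these compounds alone.

Working notes on the series

Of the compounds shown here, three have been tested in a functional assay on A 172 cells (Homo sapiens) for cytotoxicity, read by colorimetric assay and MTT assay; a higher number here means a weaker inhibitor, a lower number a stronger inhibitor. Compound 1, `COc1ccc(-c2cc3cccc(OC)c3nc2O)cc1`, gives 10000 nM. Compound 2, `COc1cc(OC)c2cc(-c3ccc(OCc4ccccc4)cc3)c(O)nc2c1`, gives 10000 nM. Compound 3, `CCOC(=O)Cn1c(=O)c(-c2ccc(OC)cc2)cc2c(OC)cc(OC)cc21`, gives 10000 nM. At the digits recorded, compound 3 stands level with compound 1 and with compound 2; neither gap is more than the usual scatter of this assay, so the three compounds show no separation from one another on the numbers in hand.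

The next compound in the series is compound 4, `COc1ccc(-c2cc3c(OC)cc(OC)cc3n(CCC(=O)OCc3ccccc3)c2=O)cc1`. It differs from compound 3 in one place: (benzyloxycarbonyl)methyl in place of ethoxycarbonyl on a saturated chain carbon bound to an aromatic nitrogen. For the measured compounds named here, no step between two measured compounds has been recorded, so there is no measured precedent for a change of this kind on the chain bound to the aromatic nitrogen.

On that footing the expectation for this assay is a step of no size beyond the scatter, no change at the digits printed from compound 3 to compound 4 (within the scatter), because compound 3 gives 10000 nM and compounds 1 and 2 sit at the same level despite their own differences from it. Compound 4 is therefore estimated at 10000 nM, with a range from 4000 nM to 10000 nM, and it is expected that the assay may again report no more than a ceiling for it.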

Compound 4, half-maximal inhibitory concentration: 10000 nM
Estimate against measurement, compound 4: no gap at the digits printed, and the stated range covers the measured number.
By their numbers in this assay, from the lowest: compounds 1, 2, 3 and 4 (each within the scatter of the next).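

Working notes on the series, continued

In this assay, for the compounds shown here, replacing ethoxycarbonyl with (benzyloxycarbonyl)methyl on a saturated chain carbon bound to an aromatic nitrogen gives no change at the digits printed from compound 3 to compound 4 (within the scatter), the first step read between two compounds that differ in one place. The earlier compounds shown here offered no such reading, and this step shows that the larger group, with 11 heavy atoms in place of 5 and one six-membered aromatic ring of carbon only, separates compound 4 from compound 3 by nothing beyond the scatter, while the count of hydrogen-bond acceptors and the absence of hydrogen-bond donors and net charge stay as they were. No supporting measurement bears on this result, so the step stands as an observation at this one position and for this one exchange.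

As far as these compounds go, whether a carboxylic acid or an amine at the end of this chain would move the number away from that of compound 3 remains open. Also open is whether any change at this place can separate a compound from this level in this assay, as all four compounds shown stand at the same printed number.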